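Replacing isopropyl with 2-carboxyethyl in compound 3

This account rests on a few compounds, and the source may have more. Where it says the series, first, only, none or still open, it means among the compounds named here.

Of the compounds shown here, three sharing one core have been measured in a functional assay on PC-3 cells (Homo sapiens) for antiproliferative activity, read by MTT assay, with a stated time of 24 h; a lower number here means a stronger inhibitor, a higher number a weaker inhibitor. Compound 1 (`CCn1c(C(=O)N[C@@H](C)C(=O)OC)ccc1C(CC)(CC)c1ccc(OCS(=O)(=O)c2ccccc2)c(C)c1`) reaches only a limit of the assay, > 50000 nM. Compound 2 (`CCn1c(C(=O)N[C@H](CO)C(C)C)ccc1C(CC)(CC)c1ccc(OCS(=O)(=O)c2ccccc2)c(C)c1`) gives 7300 nM, and compound 3 (`CCn1c(C(=O)N[C@H](C(=O)O)C(C)C)ccc1C(CC)(CC)c1ccc(OCS(=O)(=O)c2ccccc2)c(C)c1`) gives 3650 nM. The two numbers stand level, since the step of a 2.0-fold lower number from compound 2 to compound 3 (0.30 log units; within the scatter) lies within the scatter. Compound 3 thus shares the best measured position with compound 2, and the step of an at least 13-fold lower number from compound 1 to compound 3 (1.13 log units; beyond the scatter) sets it clear of the limit.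

Compound 4 (`CCn1c(C(=O)N[C@@H](CCC(=O)O)C(=O)O)ccc1C(CC)(CC)c1ccc(OCS(=O)(=O)c2ccccc2)c(C)c1`) differs from compound 3 in one place: 2-carboxyethyl in place of isopropyl on a saturated chain carbon bound to an amide-type nitrogen and a carbonyl carbon. Among the measured compounds shown here, no measured step makes this change directly. The step of a 2.0-fold lower number from compound 2 to compound 3 (0.30 log units; within the scatter) shows that a carboxy group in place of hydroxymethyl brought no change beyond the scatter. Compound 1, which has no isopropyl but also differs by its ester, sits at > 50000 nM, so a modest loss is expected in this assay. The expected step is a 1.9-fold higher number from compound 3 to compound 4 (0.28 log units; within the scatter), a small rise in the number. Compound 4 is estimated at 7000 nM, within an expected range of 2000 nM to 25000 nM.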

Compound 4, half-maximal inhibitory concentration: > 50000 nM
Compound 4: only a limit was reported; the forecaster's own chance of this, stated with the estimate: 15%; at least 7.1-fold (0.85 log units) between middle value and limit.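

In this assay, 2-carboxyethyl in place of isopropyl on the saturated chain carbon bound to an amide-type nitrogen and a carbonyl carbon gives an at least 13-fold higher number from compound 3 to compound 4 (1.13 log units; beyond the scatter), so this position does respond strongly to a change of group. The 1,3-dicarboxypropyl group in place of 1-(hydroxymethyl)-2-methylpropyl on the amide-type nitrogen likewise gives an at least 6.8-fold higher number from compound 2 to compound 4 (0.83 log units; beyond the scatter), whereas the earlier carboxy in place of hydroxymethyl stayed within the scatter. The step between compound 1 and compound 4 cannot be read, and compound 4 reaches only a limit, so the full size of its loss stays unknown: the limit of > 50000 nM in this assay, at which 2 of the 4 values shown sit.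

The compounds shown leave open whether the loss follows from the added carboxylic acid or from the departure of isopropyl. A methyl ester of the 2-carboxyethyl group, or a plain propyl chain at this carbon, would separate the two.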